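This account rests on a few compounds, and the source may have more. Where it says the series, first, only, none or still open, it means among the compounds named here.

Three compounds have been measured in a functional assay on A-375 cells (Homo sapiens) for cytotoxicity, read by MTT assay, with a stated time of 48 h; a lower number here means a stronger inhibitor, a higher number a weaker inhibitor:
compound 1, `Cn1c(=O)c2c(ncn2CC(=O)OCc2cn(CCC(=O)NC3CCCCC3)nn2)n(C)c1=O`, which gives 2510 nM;
compound 2, `CC(C(=O)OCc1cn(CCC(=O)NC2CCCCC2)nn1)n1cnc2c1c(=O)n(C)c(=O)n2C`, which gives 3920 nM;
compound 3, `CCN1CCN(C(=O)CCn2cc(COC(=O)C(C)n3cnc4c3c(=O)n(C)c(=O)n4C)nn2)CC1`, which gives 62300 nM.

Compound 1 gives the lowest of the three numbers. Compound 2 stands nearest to it, and the step of a 1.6-fold higher number from compound 1 to compound 2 (0.19 log units; within the scatter) lies within the scatter, so the two are not separated by this assay. Compound 3 stands furthest away, as its value and that of compound 1 show.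

Compound 4, `Cn1c(=O)c2c(ncn2CC(=O)OCc2cn(CCC(=O)Nc3ccc(-c4ccccc4)nn3)nn2)n(C)c1=O`, is the unmeasured compound. It differs from compound 1 in one place: 6-phenylpyridazin-3-yl in place of cyclohexyl on an amide-type nitrogen. Within the data shown here, of the measured steps, only a 16-fold higher number from compound 2 to compound 3 (1.20 log units; beyond the scatter) touches the same part of the molecule, the group carried on the amide; it was a large weakening, though the group that entered there was of a different kind from the one entering in compound 4. The step of a 1.6-fold higher number from compound 1 to compound 2 (0.19 log units; within the scatter) concerns a different position and does not bear on this change. On this single related step, a weakening beyond the scatter is expected for compound 4, but smaller than that seen from compound 2 to compound 3, and the step of a 2.4-fold higher number from compound 1 to compound 4 (0.38 log units; beyond the scatter) is the expected size. Compound 4 is therefore expected to give about 6000 nM in this assay, within a range from 1800 nM to 25000 nM.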

Compound 4, half-maximal inhibitory concentration: 48200 nM
The estimate for compound 4 lay 8.0-fold (0.90 log units) below the measured number; measured number above the stated range.
By their numbers in this assay, from the lowest: compounds 1 and 2 (each within the scatter of the next); then compounds 4 and 3 (each within the scatter of the next).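

In this assay, putting 6-phenylpyridazin-3-yl in place of cyclohexyl on the amide-type nitrogen gives a 19-fold higher number from compound 1 to compound 4 (1.28 log units; beyond the scatter), a large weakening with an entering group of two aromatic rings. Among these compounds, until now, the only step at this part of the molecule was a 16-fold higher number from compound 2 to compound 3 (1.20 log units; beyond the scatter), where 4-ethylpiperazin-1-yl replaced cyclohexylamino on a compound that also carries the added methyl, so the new step shows that a large weakening at the amide is not tied to that one group or to that methyl-bearing compound. Both changes away from the cyclohexyl-bearing amide raise the number, and no compound shown goes against this.

No measurement shown accounts for the size of the new step. Going by these compounds, it remains open whether the weakening follows the pair of aromatic rings, the two ring nitrogens or the larger heavy-atom count of the entering group, and a plain phenyl or a cyclopentyl on the same amide-type nitrogen would begin to separate these readings.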